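Naphthalen-1-yl replacing 4-(tert-butyl)phenyl on the shared core

The source may report more compounds than this note shows. Statements on the series, on what has been measured and on what is new or still open speak of the compounds shown alone.

In an ADME assay on L6 cells (Rattus norvegicus) for cytotoxicity, read by resazurin assay (on this read-out lower numbers stand for stronger inhibition and higher numbers for weaker inhibition), compound 1 `N=C(N)c1ccc2[nH]c(-c3ccc4nc(-c5ccccc5F)[nH]c4c3)nc2c1` gives 26.8 ug/mL while compound 2 `CC(C)(C)c1ccc(-c2nc3ccc(-c4nc5cc(C(=N)N)ccc5[nH]4)cc3[nH]2)cc1` gives 13 ug/mL and compound 3 `N=C(N)c1ccc2[nH]c(-c3ccc4nc(-c5ccc(Oc6ccc(Cl)cc6)cc5)[nH]c4c3)nc2c1` gives 46 ug/mL with all three built on one shared core. Compound 2 holds the lowest of the three numbers, and its steps to both others lie beyond the scatter.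

Compound 4 `N=C(N)c1ccc2[nH]c(-c3ccc4nc(-c5cccc6ccccc56)[nH]c4c3)nc2c1` has not yet been measured. It carries naphthalen-1-yl in place of 4-(tert-butyl)phenyl on an aromatic carbon, and the difference naphthalen-1-yl in place of 4-(tert-butyl)phenyl on an aromatic carbon is confined to that one group.

Within the data shown here, two measured steps bear on this change. Replacing 2-fluorophenyl with 4-(tert-butyl)phenyl gave a 2.1-fold lower number from compound 1 to compound 2 (0.31 log units; beyond the scatter) and replacing tert-butyl with 4-chlorophenoxy gave a 3.5-fold higher number from compound 2 to compound 3 (0.55 log units; beyond the scatter) and both are modest. Neither of these compounds carries naphthalen-1-yl, so they offer only a rough guide. Since compound 2 sits lowest at 13 ug/mL and the other two compounds both read higher, a modest upward step is expected rather than a large one. The expected step is a 1.8-fold higher number from compound 2 to compound 4 (0.27 log units; within the scatter) on this reasoning. Compound 4 is estimated at 24 ug/mL with 10 ug/mL to 55 ug/mL as the expected range.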

Compound 4, half-maximal inhibitory concentration: 8.72 ug/mL
Estimate against measurement, compound 4: 2.8-fold (0.44 log units) above; the whole stated range lies above it.
By their numbers in this assay, from the lowest: compounds 4 and 2 (each within the scatter of the next); then compounds 1 and 3 (each within the scatter of the next).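

In this assay, exchanging 4-(tert-butyl)phenyl for naphthalen-1-yl keeps the count of 10 heavy atoms at this carbon between two ring nitrogen atoms but adds a second six-membered aromatic ring of carbon only, and it gives a 1.5-fold lower number from compound 2 to compound 4 (0.17 log units; within the scatter). This shows that a two-ring aromatic group can stand here with the number remaining within the scatter of that of the tert-butyl compound, something the earlier single-ring and phenoxy-linked groups could not show. The same group in place of 2-fluorophenyl gives a 3.1-fold lower number from compound 1 to compound 4 (0.49 log units; beyond the scatter), which places compounds 4 and 2 together as the low pair of the series, although no measurement shown here bears on what lies behind these numbers.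

On these data alone, all four groups at this position are carbon-rich aromatic groups, so it remains open how the number would respond to a saturated ring such as cyclohexyl, or to a chain ending in an amine or a carboxylic acid. As far as these compounds go, the amidine end of the shared core is also the same throughout, so the contribution of that group to the values in this assay remains unknown.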